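Trimming the Amino Chain on Compound 1

A few compounds are considered here, and "the series" means these few. Any claim that something is new, unique, unknown or untested is made for them only; others in the source may bear on it.

Going by the values given here, compound 1 `CCNc1cc(C#Cc2ccc(F)s2)nc2c1ncn2[C@H]1[C@H](O)[C@H](O)[C@]2(C(=O)NC)C[C@H]12` gives the lowest of the two numbers so far: in an assay on HEK293 cells for displacement of a labelled ligand from adenosine receptor A3 (Mus musculus) (on this read-out lower numbers stand for stronger inhibition and higher numbers for weaker inhibition), compound 1 gives 25 nM. Compound 2 `CNC(=O)[C@H]1O[C@@H](n2cnc3c(NC)cc(C#Cc4ccc(F)s4)nc32)[C@H](O)[C@@H]1O`, built on a different core, in this assay gives 1200 nM, a much weaker result. Among the compounds with values here, compound 3 `CNC(=O)[C@@]12C[C@@H]1[C@@H](n1cnc3c(NC)cc(C#Cc4ccc(F)s4)nc31)[C@H](O)[C@@H]2O` keeps the core of compound 1 and differs only by hydrogen in place of methyl on a saturated chain carbon bound to a nitrogen on an aromatic ring, with no measured pair showing this change. Since the amino chain is shortened by a single carbon, the expected step from compound 1 to compound 3 is a 1.4-fold higher number from compound 1 to compound 3 (0.15 log units; within the scatter), within the usual scatter. Compound 3 is therefore estimated at 35 nM, in a range of 10 nM to 120 nM.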

Compound 3, inhibition constant: 37 nM
Compound 3: middle estimate off by 1.1-fold (0.02 log units), on the low side; the range from low to high includes it.
By their numbers in this assay, from the lowest: compounds 1 and 3 (each within the scatter of the next); then compound 2.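

Shortening ethylamino to methylamino on the shared core gives a 1.5-fold higher number from compound 1 to compound 3 (0.17 log units; within the scatter) in this assay. This first measured pair for the change shows that, at this position, removing one carbon from the chain leaves the binding result indistinguishable from that of compound 1, so the ethyl group is not required here. Nothing available explains why the two compounds stay so close.

On these data alone, whether a longer chain such as propylamino would keep this result remains open. So does the effect of a bare amino group, with no chain at all.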